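Acetylation of the ring hydroxyl in compound 3

The source may report more compounds than this note shows. Statements on the series, on what has been measured and on what is new or still open speak of the compounds shown alone.

The series shares the core of compound 1 `COC1=C(OC)[C@H](O)[C@H](C/C=C(\C)CC/C=C(\C)CCC=C(C)C)[C@@H](C)C1=O` and varies along the chain and at the ring hydroxyl. In a functional assay on A549 cells (Homo sapiens) for inhibition, read by sulforhodamine B assay, with a stated time of 48 h (a higher number here means a weaker inhibitor of growth, a lower number a stronger inhibitor of growth), compound 1 gives 5700 nM. Compound 3 `COC1=C(OC)[C@H](O)[C@H](C/C=C(\C)CC/C=C(\C)C[C@H](O)C=C(C)C)[C@@H](C)C1=O` carries an added hydroxy on the chain; in this assay compound 3 gives 9600 nM, and the step is a 1.7-fold higher number from compound 1 to compound 3 (0.23 log units; within the scatter). Compound 2 `COC1=C(OC)[C@H](OC(C)=O)[C@H](C/C=C(\C)CC/C=C(\C)C[C@H](O)/C=C(\C)CO)[C@@H](C)C1=O` bears the ring acetate together with a hydroxymethyl-bearing chain end; in this assay compound 2 gives 29000 nM. Among the three numbers compound 3 stands second highest, within the scatter of compound 1 and separated from compound 2 by a gap beyond the scatter.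

Compound 4 `COC1=C(OC)[C@H](OC(C)=O)[C@H](C/C=C(\C)CC/C=C(\C)C[C@H](O)C=C(C)C)[C@@H](C)C1=O` is compound 3 with acetyl in place of hydrogen on an oxygen on a saturated carbon. Among the compounds with values here, no measured step isolates this change. Compound 2 differs from compound 3 in two places at once, so its higher number cannot be assigned to the acetyl alone. Within the data shown here, the only one-place step in the set, a 1.7-fold higher number from compound 1 to compound 3 (0.23 log units; within the scatter), concerns the chain rather than this oxygen, and it lies within the scatter. The step of a 1.4-fold higher number from compound 3 to compound 4 (0.13 log units; within the scatter) is therefore expected to be modest, leaning toward a higher number. That lean rests on compound 2, whose acetate-bearing structure gives 29000 nM. For compound 4 the estimate in this assay is 13000 nM, with a range from 5000 nM to 35000 nM.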

Compound 4, concentration for 50% growth inhibition: 20700 nM
Beside the measured number, compound 4's estimate is 1.6-fold (0.20 log units) below it; the range from low to high includes it.
By their numbers in this assay, from the lowest: compounds 1 and 3 (each within the scatter of the next); then compounds 4 and 2 (each within the scatter of the next).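

Acetylation at this oxygen on a saturated carbon can now be read by itself in this assay: hydroxy to acetoxy gives a 2.2-fold higher number from compound 3 to compound 4 (0.33 log units; beyond the scatter), a modest step but one beyond the scatter, which the earlier compounds could not separate from the chain difference in compound 2. The chain-end hydroxy is now read separately as well: a 1.4-fold lower number from compound 2 to compound 4 (0.15 log units; within the scatter) lies within the scatter, so this one-place difference does not separate the two acetates in this assay. The added chain hydroxy also gives steps on the free-hydroxyl and acetate cores that do not separate from each other, so its step stays small whichever group sits at the ring oxygen: the same change on two cores in this assay, a 1.7-fold higher number (0.23 log units; within the scatter) from compound 1 to compound 3 and a 1.4-fold higher number (0.15 log units; within the scatter) from compound 4 to compound 2, 1.2-fold (0.08 log units) apart, within the scatter of two such steps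

The acetyl step is read on one pair only, so the compounds shown leave open whether it recurs on the core of compound 1, without the chain hydroxy. They also leave open how a methyl ether or a butanoyl ester at this oxygen would compare with the hydroxy and acetoxy forms.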